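A few compounds are considered here, and "the series" means these few. Any claim that something is new, unique, unknown or untested is made for them only; others in the source may bear on it.

Measured compounds in a functional assay on SGC-7901 cells (Homo sapiens) for antiproliferative activity, read by MTT assay, with a stated time of 24 h; a higher number here means a weaker inhibitor, a lower number a stronger inhibitor:
compound 1, `Cc1cccc(-n2cc(-c3ccccc3NS(=O)(=O)c3c[nH]c(=O)[nH]c3=O)nn2)c1`, 3510 nM
compound 2, `Cc1ccc(-n2cc(-c3ccccc3NS(=O)(=O)c3c[nH]c(=O)[nH]c3=O)nn2)cc1`, 6390 nM
compound 3, `O=c1[nH]cc(S(=O)(=O)Nc2ccccc2-c2cn(-c3ccc(F)cc3)nn2)c(=O)[nH]1`, > 20000 nM

The entry for compound 3 is a limit of the assay, not a number, (the limit of > 20000 nM in this assay, at which 1 of the 3 values shown sits). On the numbers shown compound 3 therefore sits at the weak end of the three, with the steps of an at least 5.6-fold higher number from compound 1 to compound 3 (0.75 log units; beyond the scatter) and an at least 3.1-fold higher number from compound 2 to compound 3 (0.49 log units; beyond the scatter) both running toward it; the step of a 1.8-fold higher number from compound 1 to compound 2 (0.26 log units; within the scatter) adds nothing beyond the scatter.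

Compound 4, `O=c1[nH]cc(S(=O)(=O)Nc2ccccc2-c2cn(-c3ccccc3Cl)nn2)c(=O)[nH]1`, differs from compound 3 by 2-chlorophenyl in place of 4-fluorophenyl on an aromatic nitrogen. Among the compounds with values here, no measured step pairs a 4-fluorophenyl against a 2-chlorophenyl, so only indirect bearing exists: the two steps into compound 3 show that the group on the triazole nitrogen can move this assay by a modest amount, and the methyl pair shows that a shift of the same group can also leave it unchanged. Because compound 3 is known only as a limit, the direction of the next step cannot be fixed; a number near the limit, or a modest return toward compounds 1 and 2, is the expectation. Compound 4 is expected to give 12000 nM, within 4000 nM to 40000 nM. The expected step is then an at least 1.6-fold lower number from compound 3 to compound 4 (0.22 log units; that floor lies within the scatter).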

Compound 4, half-maximal inhibitory concentration: 6520 nM
Compound 4: the middle estimate sits 1.8-fold (0.26 log units) above what was measured; the measured number falls inside the stated range.
By their numbers in this assay, from the lowest: compounds 1, 2 and 4 (each within the scatter of the next). At a limit, above all of these: compound 3.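

In this assay, 2-chlorophenyl in place of 4-fluorophenyl on the aromatic nitrogen gives an at least 3.0-fold lower number from compound 3 to compound 4 (0.48 log units; beyond the scatter), so a halogen on this phenyl does not by itself set a compound at the weak end of the series. From the compounds shown here alone, the true size of that step stays unknown, since the entry for compound 3 is a limit of the assay and not a number: the limit of > 20000 nM in this assay, at which 1 of the 4 values shown sits. Against the two methylphenyl groups, 2-chlorophenyl gives a 1.0-fold higher number from compound 2 to compound 4 (0.01 log units; within the scatter) and a 1.9-fold higher number from compound 1 to compound 4 (0.27 log units; within the scatter), so methyl and chloro groups read alike here, with 4-fluorophenyl the only group set apart.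

Going by these compounds, whether the fluorine itself or its place on the phenyl sets compound 3 apart remains open, and 4-chlorophenyl and 2-fluorophenyl would separate the two. Also open, on these data alone, is how this position responds to a phenyl bearing an amine or a carboxylic acid.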